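Oxolan-3-yl to oxolan-2-yl on compound 1

This account rests on a few compounds, and the source may have more. Where it says the series, first, only, none or still open, it means among the compounds named here.

- compound 1 `Cc1cc(C)c(CN2CCc3c(Cl)cc([C@H](CO)[C@H]4CCOC4)c(Cl)c3C2=O)c(=O)[nH]1` gives 2.9 10^-6 cm/s
- compound 2 `COC(c1cc(Cl)c2c(c1Cl)C(=O)N(Cc1c(C)cc(C)[nH]c1=O)CC2)C1CCOC1` gives 17.1 10^-6 cm/s; 18.7 10^-6 cm/s; 15.4 10^-6 cm/s; 18.4 10^-6 cm/s (4 entries)
- compound 3 `COC(c1cc(Cl)c2c(c1Cl)C(=O)N(Cc1c(C)cc(C)[nH]c1=O)CC2)C1CCOCC1` gives 13.3 10^-6 cm/s; 16.5 10^-6 cm/s (2 entries)

In an ADME assay on MDCK cells (Canis lupus familiaris) for permeability, read by LC-MS, with a stated time of 90 min, tested at 2 uM (on this read-out higher numbers stand for higher permeability and lower numbers for lower permeability), compound 1 rests on the single entry 2.9 10^-6 cm/s and lies lower than every entry of compound 2 and compound 3. Those two carry several entries each, and their values overlap within the usual scatter.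

The next compound to be read is compound 4 `Cc1cc(C)c(CN2CCc3c(Cl)cc([C@H](CO)[C@H]4CCCO4)c(Cl)c3C2=O)c(=O)[nH]1` and it keeps the shared core. The change from compound 1 is oxolan-2-yl in place of oxolan-3-yl on a saturated chain carbon bound to an aromatic carbon and a saturated chain carbon with oxolan-2-yl in place of oxolan-3-yl on a saturated chain carbon bound to an aromatic carbon and a saturated chain carbon. The two have the same atoms, joined differently.

For the measured compounds named here, no measured pair isolates this kind of change. In this assay no step beyond the scatter is therefore expected, and compound 1 at 2.9 10^-6 cm/s remains the anchor. The estimated 1.1-fold higher number from compound 1 to compound 4 (0.04 log units; within the scatter) is expected to stay within that scatter. For compound 4 the estimated value is 3.2 10^-6 cm/s with an expected range from 1.5 10^-6 cm/s to 7 10^-6 cm/s for the coming measurement.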

Compound 4, apparent permeability: 4.1 10^-6 cm/s
Compound 4: middle estimate off by 1.3-fold (0.11 log units), on the low side, and the stated range covers the measured number.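

For the compounds shown here, with oxolan-2-yl in place of oxolan-3-yl on a saturated chain carbon bound to an aromatic carbon and a saturated chain carbon, this assay records a 1.4-fold higher number from compound 1 to compound 4 (0.15 log units; within the scatter) and gives the first step that isolates one change at this position. The two isomeric rings therefore cannot be told apart on this read-out, so moving the ring attachment leaves the number in place within the scatter. Compound 1 and compound 4 each rest on one number, while repeat entries on another compound show how single readings spread: the several entries of compound 2 in this assay, 17.1 10^-6 cm/s; 18.7 10^-6 cm/s; 15.4 10^-6 cm/s; 18.4 10^-6 cm/s (4 entries).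

Going by these compounds alone, compound 2 and compound 3 differ from compound 4 in more than one place, so no step to them can be read. Open, on these data alone, is whether cyclopentyl in place of the oxolane ring, or an amine at the same place, would move the number beyond the scatter.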